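Shortening the hydroxamate chain of compound 1

The source may report more compounds than this note shows. Statements on the series, on what has been measured and on what is new or still open speak of the compounds shown alone.

Values in a functional assay on A549 cells (Homo sapiens) for antiproliferative activity, read by sulforhodamine B assay, with a stated time of 48 h (a lower number here means a stronger inhibitor of growth, a higher number a weaker inhibitor of growth), so far

compound 1 `CC(C)CCc1c(OCCCCCCC(=O)NO)ccc2c1OC(=O)CC2` gives > 30000 nM (a limit of the assay)
compound 2 `CC(C)CCc1c(OCCCCC(=O)NO)ccc2ccc(=O)oc12` gives 2760 nM

In this assay compound 1 gives > 30000 nM as a limit of the assay and not a number. Its place in the series is therefore known only as that limit.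

Compound 3 `CC(C)CCc1c(OCCCCC(=O)NO)ccc2c1OC(=O)CC2` has not yet been measured. It differs from compound 1 by the change hydroxycarbamoyl in place of 2-(hydroxycarbamoyl)ethyl on a saturated chain carbon, four bonds along the chain from an oxygen on an aromatic ring with hydroxycarbamoyl in place of 2-(hydroxycarbamoyl)ethyl on a saturated chain carbon, four bonds along the chain from an oxygen on an aromatic ring. Read one bond further out, 5-(hydroxycarbamoyl)pentyl becomes 3-(hydroxycarbamoyl)propyl.

Going by the values given here, no measured step bears directly on this change. Compound 2 gives 2760 nM and shows that a number can be obtained in this small set. A shift towards stronger growth inhibition is expected, though its size is uncertain without a number for compound 1. The estimated step is an at least 3.0-fold lower number from compound 1 to compound 3 (0.47 log units; beyond the scatter) and remains tentative. For compound 3 the expected value is 10000 nM with an estimated range from 3000 nM to 30000 nM and a real chance of another limit.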

Compound 3, concentration for 50% growth inhibition: > 30000 nM
Compound 3: only a limit was reported (the forecaster's own chance of this, stated with the estimate: 35%); at least 3.0-fold (0.47 log units) between middle value and limit.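

In this assay compound 1 and compound 3 each give only a limit of the assay, so no step can be read from compound 1 to compound 3 because both sit at the same limit: the limit of > 30000 nM in this assay, at which 2 of the 3 values shown sit.

The compounds shown leave open whether 3-(hydroxycarbamoyl)propyl in place of 5-(hydroxycarbamoyl)pentyl on the shared core changes growth inhibition at all.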